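A few compounds are considered here, and "the series" means these few. Any claim that something is new, unique, unknown or untested is made for them only; others in the source may bear on it.

Of the compounds shown here, two have numbers so far in a functional assay on HeLa cells (Homo sapiens) for antiproliferative activity, read by MTT assay, with a stated time of 48 h; on this read-out higher numbers stand for weaker inhibition and lower numbers for stronger inhibition. Compound 2 `COc1ccc(-c2nn(-c3ccccc3)cc2-c2nc3cc(C)ccc3[nH]2)cc1` gives 3290 nM, the lower of the two, and compound 1 `Cc1cc2nc(-c3cn(-c4ccccc4)nc3-c3ccc(Cl)cc3)[nH]c2cc1C` gives 21800 nM, a gap beyond the scatter. These two compounds differ in more than one place, so the gap cannot be assigned to any single change.

Compound 3 `COc1ccc(-c2nn(-c3ccccc3)cc2-c2nc3cc(C)c(C)cc3[nH]2)cc1` departs from compound 2 in one place only: methyl in place of hydrogen on an aromatic carbon, ortho to a methyl group. Among the measured compounds shown here, no measured pair isolates this change, so any expectation for it rests on thin evidence. Compound 1 carries the same methyl group, and its 21800 nM tilts the expectation weakly towards a higher number in this assay, although compound 1 also differs elsewhere. The expected move, a 1.5-fold higher number from compound 2 to compound 3 (0.18 log units; within the scatter), is small and may not exceed the scatter. For compound 3 the estimated value is 5000 nM, with an expected range from 1500 nM to 16000 nM.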

Compound 3, half-maximal inhibitory concentration: 8930 nM
Beside the measured number, compound 3's estimate is 1.8-fold (0.25 log units) below it; the measured number falls inside the stated range.
By their numbers in this assay, from the lowest: compound 2; then compound 3; then compound 1.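

In this assay, among the compounds shown here, the methyl on the aromatic carbon ortho to a methyl group gives a 2.7-fold higher number from compound 2 to compound 3 (0.43 log units; beyond the scatter), the first measured pair to isolate this change and a step that shows this position is not indifferent to one added heavy atom on the methoxy-bearing compounds. Compound 3 also isolates a second change, methoxy in place of chloro on an aromatic carbon, which gives a 2.4-fold lower number from compound 1 to compound 3 (0.39 log units; beyond the scatter), so the gap between compound 1 and compound 2 can now be followed through two single changes, each beyond the scatter. No measurement at hand bears on why either step has its size.

For the compounds shown here, each change has been read on one background only, so it remains open whether methyl in place of hydrogen moves the number the same way when chloro replaces methoxy, and whether methoxy in place of chloro does so with the single methyl group of compound 2. Also open, going by these compounds, is how this aromatic carbon responds to groups of another kind, such as an ethyl chain, an amine or a carboxylic acid, in place of the methyl of compound 3.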